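Aryl amide variation at the cyclopropane dicarboxamide terminus

The compounds below may be only part of what the source reports. "The series", "measured", "known", "first", "only" and "open" are said of these compounds alone.

Compound 3 `CN(C)C(=O)c1cc2cnc(Nc3ccc(NC(=O)C4(C(=O)Nc5cccc(Br)c5)CC4)cc3)nc2n1C1CCCC1` stands highest of the three numbers in a functional assay on T47D cells (Homo sapiens) for inhibition, read by CCK-8 assay, with a stated time of 72 h, tested at 10 uM; a higher number here means more inhibition of growth at the concentration tested, a lower number less inhibition of growth; compound 3 gives 94.6%. Compound 1 `CN(C)C(=O)c1cc2cnc(Nc3ccc(NC(=O)C4(C(=O)Nc5ccc(F)cc5)CC4)cc3F)nc2n1C1CCCC1` gives 67.9% and compound 2 `CN(C)C(=O)c1cc2cnc(Nc3ccc(NC(=O)C4(C(=O)Nc5ccc(Cl)c(C(F)(F)F)c5)CC4)cc3)nc2n1C1CCCC1` gives 55.8%, both beyond the scatter below compound 3. Compound 4 `COc1ccc(NC(=O)C2(C(=O)Nc3ccc(Nc4ncc5cc(C(=O)N(C)C)n(C6CCCC6)c5n4)cc3)CC2)cc1` differs from compound 3 by 4-methoxyphenyl in place of 3-bromophenyl on an amide-type nitrogen. For the measured compounds named here, the one measured step at this position, a number 38.8 percentage points higher from compound 2 to compound 3 (beyond the scatter), shows that the aryl group on this amide nitrogen can move the number widely. Going by the values given here, no measured step reaches 4-methoxyphenyl, and compound 1 with 4-fluorophenyl sits well below compound 3, so compound 4 is expected to fall, with a number 29.6 percentage points lower from compound 3 to compound 4 (beyond the scatter) estimated. Compound 4 is therefore estimated at 65%, within 40% to 88%.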

Compound 4, percent growth inhibition at one concentration: 96.1%
The estimate for compound 4 lay 31.1 percentage points below the measured number, and the stated range ends below it.
By their numbers in this assay, from the lowest: compound 2; then compound 1; then compounds 3 and 4 (each within the scatter of the next).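

In this assay, a number 1.5 percentage points higher from compound 3 to compound 4 (within the scatter), so 3-bromophenyl and 4-methoxyphenyl on this amide-type nitrogen cannot be told apart, although they differ in the substituent and its place on the ring. With a number 40.3 percentage points higher from compound 2 to compound 4 (beyond the scatter), a second large step now separates 4-chloro-3-(trifluoromethyl)phenyl from another aryl group at this position, so compound 2 stands low against both. Nothing measured here bears on why these steps have their sizes.

Open, from the compounds shown here alone, is whether an unsubstituted phenyl, a pyridine ring or a benzyl group on this nitrogen would stay level with compound 3 and compound 4.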